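The source may hold more compounds than are shown below. What is called first, only, known or untested is meant among the compounds shown, and "the series" means these compounds.

Compound 1, `COc1ccc(NC(=O)c2csc(Cc3c(Cl)cccc3Cl)n2)cc1`, in an assay on CHO cells, read by calcium flux (a higher number here means a weaker inhibitor, a lower number a stronger inhibitor), gives > 4000 nM, which is a limit of the assay rather than a number.
Compound 2, `N#Cc1ccc(NC(=O)c2csc(Cc3c(Cl)cccc3Cl)n2)cc1`, in this assay gives 450 nM.

Going by the values given here, compound 2 therefore holds the only numerical value in this assay; the other result is a limit. Compound 3, `O=C(Nc1ccc(C(F)(F)F)cc1)c1csc(Cc2c(Cl)cccc2Cl)n1`, has not yet been measured. It differs from compound 2 as follows: trifluoromethyl in place of cyano on an aromatic carbon. Among the compounds with values here, one measured step touches the same aromatic carbon: an at least 8.8-fold lower number from compound 1 to compound 2 (0.94 log units; beyond the scatter). That step shows that exchanging the group on this carbon can move the number well beyond the scatter, but it compared methoxy with cyano, not cyano with trifluoromethyl, and one of its two ends rests on (the limit of > 4000 nM in this assay, at which 1 of the 2 values shown sits). Within the data shown here, with no direct precedent for trifluoromethyl, only a small rise in the number, close to the scatter, is expected: a 1.6-fold higher number from compound 2 to compound 3 (0.19 log units; within the scatter). Compound 3 is estimated at 700 nM, with a likely range from 250 nM to 2500 nM.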

Compound 3, half-maximal inhibitory concentration: 140 nM
Compound 3: the middle estimate sits 5.0-fold (0.70 log units) above what was measured; the measured number lies below the stated range.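

Going by these compounds alone, compound 2 and compound 3 give the first comparison at this aromatic carbon with a true number at both ends: in this assay, trifluoromethyl in place of cyano gives a 3.2-fold lower number from compound 2 to compound 3 (0.51 log units; beyond the scatter). Trifluoromethyl in place of methoxy gives an at least 28-fold lower number from compound 1 to compound 3 (1.45 log units; beyond the scatter), which makes compound 3 the strongest inhibitor of the three and shows that cyano was not the best of the groups shown at this carbon. The size of that second step is open-ended, as the result for compound 1 is a limit: the limit of > 4000 nM in this assay, at which 1 of the 3 values shown sits.

The compounds shown leave open how an amine, a carboxylic acid or a longer chain would fare on this same carbon. They also leave open whether trifluoromethyl would give a similar result on another carbon of this ring.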